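This account rests on a few compounds, and the source may have more. Where it says the series, first, only, none or still open, it means among the compounds named here.

Working notes on the series. Compound 1 `C#CCN(C)CCCOc1cc(NC(=O)CCCCCCC(=O)NO)c(Cl)cc1Cl` gives 50600 nM in a functional assay on U-251 cells (Homo sapiens) for inhibition, read by MTT assay, with a stated time of 48 h (a lower number here means a stronger inhibitor, a higher number a weaker inhibitor), the highest of the three numbers recorded so far and beyond the scatter from both others. Compound 2 `C#CCN(C)CCCOc1ccc(NC(=O)CCCCCCC(=O)NO)cc1Cl` gives 2830 nM in this assay, and compound 3 `C#CCN(C)CCCOc1cccc(NC(=O)CCCCCCC(=O)NO)c1Cl` gives 5820 nM in this assay. Among the measured compounds shown here, each of these two carries a single chloro group on the shared core, whereas compound 1 carries two, and no direct single-point step between any of the measured pair is available, so their values can only be set side by side.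

Compound 4 `C#CCN(C)CCCOc1cc(NC(=O)CCCCCCC(=O)NO)ccc1Cl` has not yet been measured in this assay. It differs from compound 1 in one place: hydrogen in place of chloro on an aromatic carbon. The result is a third single-chloro member of the series.

The expectation for compound 4 rests on the two single-chloro compounds, because compound 2 gives 2830 nM and because compound 3 gives 5820 nM, both far under compound 1. The step expected here, a 10-fold lower number from compound 1 to compound 4 (1.01 log units; beyond the scatter), runs downward and beyond the scatter. Compound 4 is estimated at 5000 nM, with a range of 1500 nM to 16000 nM.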

Compound 4, half-maximal inhibitory concentration: 120 nM
Beside the measured number, compound 4's estimate is 42-fold (1.62 log units) above it, and the stated range ends above it.
By their numbers in this assay, from the lowest: compound 4; then compound 2; then compound 3; then compound 1.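

In this assay, replacing the chloro on this aromatic carbon, ortho to a large group and para to the 3-(methyl(propargyl)amino)propoxy group, with hydrogen gives a 420-fold lower number from compound 1 to compound 4 (2.62 log units; beyond the scatter) in a single exchange. Among the compounds shown here, this is the first step that can be read at one place, and it shows that this one position alone moves the number by a large margin, beyond the scatter, with a single chlorine atom leaving and no ring, donor, acceptor or charge involved. Nothing at hand accounts for a step of this size.

As far as these compounds go, it remains open whether the step follows from chloro specifically or from any group here, which a fluoro, methyl or methoxy group on this carbon would test. The contribution of the remaining chloro group, meta to this carbon, also stays unresolved.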